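The source may report more compounds than this note shows. Statements on the series, on what has been measured and on what is new or still open speak of the compounds shown alone.

Working notes on the flavanone series.

Compound 1 `COc1cc(OC(C)=O)c(CC=C(C)C)c2c1C(=O)C[C@@H](c1ccc(OC(C)=O)cc1)O2` carries two acetate groups and in a functional assay on CCRF-CEM cells (Homo sapiens) for antiproliferative activity, read by MTT assay, with a stated time of 72 h (a higher number here means a weaker inhibitor, a lower number a stronger inhibitor), compound 1 gives 23.3 ug/mL. Compound 2 `COc1ccc(C2CC(=O)c3c(O)cc(OC)c(CC=C(C)C)c3O2)cc1` is reported in this assay as "not active" (no number reported), with no number attached to it. Compound 3 `CCCCCOc1ccc([C@@H]2CC(=O)c3c(OC)cc(OCCCCC)c(CC=C(C)C)c3O2)cc1`, which carries a pentyloxy group on both the core and the pendant phenyl, gives in this assay 4.3 ug/mL. Among the two compounds with a number, compound 3 stands at the lower end: its nearest neighbour is compound 1, whose number is higher by a gap that lies beyond the usual scatter of this assay. Going by the values given here, no two measured compounds differ in a single place, so no isolated single-change step is available within the measured set.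

Compound 4 `CCCCCOc1cc(OC)c2c(c1CC=C(C)C)O[C@H](c1ccc(O)cc1)CC2=O` is not yet measured. It differs from compound 3 in one place:

hydrogen in place of pentyl on an oxygen on an aromatic ring

The core of compound 4 keeps its pentyloxy group; only the pendant phenyl loses its pentyl. Among the compounds with values here, with no measured single-change step to lean on, the expectation is a moderate move toward a higher number, beyond the scatter, as indicated by the step of a 2.3-fold higher number from compound 3 to compound 4 (0.37 log units; beyond the scatter). Compound 4 is thus estimated to give 10 ug/mL in this assay, with a range from 4 ug/mL to 30 ug/mL.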

Compound 4, concentration for 50% inhibition: 5.4 ug/mL
The estimate for compound 4 lay 1.9-fold (0.27 log units) above the measured number; measured number inside the range.
By their numbers in this assay, from the lowest: compounds 3 and 4 (each within the scatter of the next); then compound 1.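

In this assay, going by these compounds alone, the exchange of 4-(pentyloxy)phenyl for 4-hydroxyphenyl gives a 1.3-fold higher number from compound 3 to compound 4 (0.10 log units; within the scatter), the first single-change step. At this place, on an oxygen on an aromatic ring, the pentyl group can therefore give way to hydrogen without a change that can be told from the scatter, so the pentyl group here is not needed for a number of this size. The earlier compounds shown here differ from one another in more than one place and could not isolate this position; this step isolates it, with the pentyloxy group on the core kept in place. Nothing at hand gives a measured reason for this tolerance.

Within the data shown here, what remains open is whether the pentyloxy group on the core tolerates the same exchange, as no step here reads that place. Also open, going by these compounds, is how a longer chain, or a chain ending in an amine or a carboxylic acid, would read on this same oxygen in this assay.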